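Removing the Chloro Group from Compound 1

The source may hold more compounds than are shown below. What is called first, only, known or untested is meant among the compounds shown, and "the series" means these compounds.

Compound 1 `CN(C)C(=O)c1cc2cnc(Nc3ccc(NC(=O)C4(C(=O)Nc5ccc(Cl)cc5)CC4)cc3)nc2n1C1CCCC1` was tested in a functional assay on T47D cells (Homo sapiens) for inhibition, read by CCK-8 assay, with a stated time of 72 h, tested at 1 uM (a lower number here means less inhibition of growth, a higher number more inhibition of growth at the concentration tested), where compound 1 gives 22.8%, the second highest of three numbers: compound 2 `COc1ccc(NC(=O)C2(C(=O)Nc3ccc(Nc4ncc5cc(C(=O)N(C)C)n(C6CCCC6)c5n4)cc3)CC2)cc1` gives 76.4% and compound 3 `CN(C)C(=O)c1cc2cnc(Nc3ccc(NC(=O)C4(C(=O)Nc5cccc(C(F)(F)F)c5)CC4)cc3)nc2n1C1CCCC1` gives 9.7%. Compound 4 `CN(C)C(=O)c1cc2cnc(Nc3ccc(NC(=O)C4(C(=O)Nc5ccccc5)CC4)cc3)nc2n1C1CCCC1` is not yet measured; it differs from compound 1 by hydrogen in place of chloro on an aromatic carbon. Among the compounds with values here, no measured step removes a group outright, but two steps alter the same aryl ring and so bear on it: a number 53.6 percentage points higher from compound 1 to compound 2 (beyond the scatter) and a number 13.1 percentage points lower from compound 1 to compound 3 (beyond the scatter). Both are large yet run in opposite directions, so the outcome for a bare ring is uncertain, and a wide range is warranted. For compound 4 a moderate rise is expected, a number 12.2 percentage points higher from compound 1 to compound 4 (beyond the scatter). Compound 4 is therefore estimated at 35%, within a range from 10% to 65%.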

Compound 4, percent growth inhibition at one concentration: 52.8%
The estimate for compound 4 lay 17.8 percentage points below the measured number, within the range that was stated.
By their numbers in this assay, from the lowest: compound 3; then compound 1; then compound 4; then compound 2.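

In this assay, the bare phenyl ring falls in the middle of the series, so the ring needs no group here to inhibit growth. Taking off chloro gives a number 30 percentage points higher from compound 1 to compound 4 (beyond the scatter), and taking off trifluoromethyl gives a number 43.1 percentage points higher from compound 3 to compound 4 (beyond the scatter), so both groups go with less inhibition than hydrogen. Only methoxy stands above hydrogen, with a number 23.6 percentage points lower from compound 2 to compound 4 (beyond the scatter), so the large rise from chloro to methoxy combines the loss of chloro with a further gain over the bare ring.

On these data alone, how an amine or a carboxylic acid on this ring would read remains open. Nothing measured here tells why these groups differ.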